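The source may hold more compounds than are shown below. What is called first, only, known or untested is meant among the compounds shown, and "the series" means these compounds.

Measured compounds:
Compound 1 `Fc1cccc(F)c1C#Cc1cncc2ccccc12`: 87.9%
Compound 2 `Cn1ncc2cc(C#Cc3c(F)cccc3F)ccc21`: 94.6%
Compound 3 `Fc1cccc(F)c1C#Cc1cnc(Cl)c2ccccc12`: 94%

In a functional assay on LS174T cells (Homo sapiens) for inhibition, with a stated time of 4 days, tested at 10 uM (a lower number here means a weaker effect, a higher number a stronger effect of the compound at the concentration tested), compound 3 gives 94%, the second highest of the three numbers; the values of compound 2 and compound 1 both lie within the scatter of it. Among the measured compounds shown here, the only step between measured compounds, a number 6.1 percentage points higher from compound 1 to compound 3 (within the scatter), was within the scatter. Compound 4 `Nc1ncc(C#Cc2c(F)cccc2F)c2ccccc12` differs from compound 3 at the same aromatic carbon: amino in place of chloro on an aromatic carbon. The step from compound 1 to compound 3 touches this position but exchanges a different pair of groups, so it bears on the change only loosely. With no step beyond the scatter anywhere in the set, the expected step is a number 4 percentage points lower from compound 3 to compound 4 (within the scatter). The estimate for compound 4 is 90%, in a range from 78% to 98%.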

Compound 4, a percentage reported as inhibition, at one concentration (the size of the read-out at that concentration, not a potency): 93.1%
Compound 4: middle estimate off by 3.1 percentage points, on the low side; measured number inside the range.
By their numbers in this assay, from the lowest: compounds 1, 4, 3 and 2 (each within the scatter of the next).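

In this assay, the step of a number 0.9 percentage points lower from compound 3 to compound 4 (within the scatter) shows that amino in place of chloro on the aromatic carbon next to the ring nitrogen stays within the scatter, although amino adds a hydrogen-bond donor. The step of a number 5.2 percentage points higher from compound 1 to compound 4 (within the scatter) also stays within the scatter, so none of the three groups compared at this carbon, hydrogen, chloro and amino, separates from the others. Nothing measured here explains this result. The compounds shown leave open whether a carboxylic acid, a methoxy group or a longer chain at this carbon would give a step beyond the scatter. They also leave open whether these three groups would separate at other concentrations.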